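From 1-methylcyclohexyl to 2-cyclohexylethyl

The source may report more compounds than this note shows. Statements on the series, on what has been measured and on what is new or still open speak of the compounds shown alone.

In a physicochemical assay for solubility, at pH 7.4 (on this read-out lower numbers stand for lower solubility and higher numbers for higher solubility), compound 1 (`CCCCCCCc1cc(-c2ccc(CNC(=O)[C@H]3NCC[C@@H]3O)cc2)n[nH]1`) gives 3.7 ug/mL and compound 3 (`CCCCCCCc1nnc(-c2ccc(CNC(=O)[C@H]3NCC[C@@H]3O)cc2)o1`) gives 2.1 ug/mL, two values within the usual scatter of each other. Compound 2 (`CC1(c2nc(-c3ccc(CNC(=O)[C@H]4NCC[C@@H]4O)cc3)no2)CCCCC1`) is the only one of the three reported as a limit, > 50 ug/mL, and not as a number. Compound 4 (`O=C(NCc1ccc(-c2noc(CCC3CCCCC3)n2)cc1)[C@H]1NCC[C@@H]1O`) changes compound 2 at one place, on an aromatic carbon: 2-cyclohexylethyl in place of 1-methylcyclohexyl on an aromatic carbon. The entering 2-cyclohexylethyl resembles the heptyl group of compound 1 at 3.7 ug/mL and compound 3 at 2.1 ug/mL more than 1-methylcyclohexyl does. A large downward step in this assay is therefore expected, estimated as an at least 8.3-fold lower number from compound 2 to compound 4 (0.92 log units; beyond the scatter). For compound 4 the expected value is 6 ug/mL, within an estimated range of 2 ug/mL to 25 ug/mL.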

Compound 4, solubility: 26 ug/mL
The estimate for compound 4 lay 4.3-fold (0.64 log units) below the measured number; the measured number lies above the stated range.
By their numbers in this assay, from the lowest: compounds 3 and 1 (each within the scatter of the next); then compound 4. At a limit, above all of these: compound 2.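

In this assay, for the compounds shown here, compound 4 gives 26 ug/mL, the first actual number for a group at this aromatic carbon of the five-membered ring. As far as these compounds go, compound 2 is reported only as a limit: the limit of > 50 ug/mL in this assay, at which 1 of the 4 values shown sits. Placing 2-cyclohexylethyl where 1-methylcyclohexyl stood gives an at least 1.9-fold lower number from compound 2 to compound 4 (0.28 log units; that floor lies within the scatter), so the true size of this change remains unknown, and it may be small or large.

The compounds shown leave open how the same place would respond to a longer chain or to a chain ending in an amine. They also leave open whether a carboxylic acid there would give a number or another limit.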